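Swapping the aryl on the carbamate nitrogen of compound 3

The source may report more compounds than this note shows. Statements on the series, on what has been measured and on what is new or still open speak of the compounds shown alone.

Of the compounds shown here, three sharing one core have been measured in an assay on NIH3T3 cells with Urotensin-2 receptor (Homo sapiens) as the target; on this read-out higher numbers stand for larger maximal responses and lower numbers for smaller maximal responses. Compound 1 `COc1ccc(C(=O)OC(CCN(C)C)c2ccc(Cl)cc2)cc1` gives 84%. Compound 2 `Cc1c(Cl)cccc1C(=O)OC(CCN(C)C)c1ccc(Cl)cc1` gives 118%, a change of a number 34 percentage points higher from compound 1 to compound 2 (beyond the scatter). Compound 3 `Cc1ccccc1NC(=O)OC(CCN(C)C)c1ccc(Cl)cc1` gives 176%, which is a number 92 percentage points higher from compound 1 to compound 3 (beyond the scatter) and a number 58 percentage points higher from compound 2 to compound 3 (beyond the scatter). Compound 3 therefore stands highest of the three, with compound 2 nearest and compound 1 furthest, both gaps beyond the scatter.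

Compound 4 `COc1ccc(NC(=O)OC(CCN(C)C)c2ccc(Cl)cc2)cc1` is not yet measured. It differs from compound 3 in one place: 4-methoxyphenyl in place of 2-methylphenyl on an amide-type nitrogen. Within the data shown here, of the measured steps, the one from compound 1 to compound 2 bears most closely on this change, since there a 4-methoxyphenyl was also the group replaced by an aryl carrying a methyl, and that step gave a number 34 percentage points higher from compound 1 to compound 2 (beyond the scatter) in favour of the methyl-bearing aryl. The step from compound 3 to compound 4 runs the other way, from a methyl-bearing aryl back to 4-methoxyphenyl, though on an amide-type nitrogen rather than a carbonyl carbon, so the comparison is only indirect. On that basis a decrease of moderate size in this assay is expected for compound 4, estimated as a number 41 percentage points lower from compound 3 to compound 4 (beyond the scatter). Compound 4 is thus expected to reach about 135%, within a range of 95% to 175%.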

Compound 4, largest response reached (reported as efficacy), in percent of the reference or control that the assay uses: 170%
The estimate for compound 4 lay 35 percentage points below the measured number; measured number inside the range.
By their numbers in this assay, from the lowest: compound 1; then compound 2; then compounds 4 and 3 (each within the scatter of the next).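

On the amide-type nitrogen, this assay gives a number 6 percentage points lower from compound 3 to compound 4 (within the scatter) and so does not separate 4-methoxyphenyl from 2-methylphenyl, which shows that this position takes either aryl without a change that can be told from the scatter. The 4-methoxyphenyl group therefore does not go with a low number wherever it stands: compound 1, with this group on a carbonyl carbon, gives 84% and compound 4, with it on the amide-type nitrogen, gives 170% while the two compounds differ only at that link. Nothing available explains why these two aryl groups read alike on the nitrogen.

Only two aryl groups are shown on this nitrogen, so it remains open whether the tolerance extends to an unsubstituted phenyl, to a saturated cyclohexyl, or to a phenyl ring carrying a carboxylic acid or an amine. From the compounds shown here alone, it is also open whether 3-chloro-2-methylphenyl on the nitrogen would read like compound 3, and what a methyl in place of the amide hydrogen would do to the maximal response.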